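Moving the ring oxygen within the oxolanyl side chain

A few compounds are considered here, and "the series" means these few. Any claim that something is new, unique, unknown or untested is made for them only; others in the source may bear on it.

Compound 2 `Cc1cc(C)c(CN2CCc3c(Cl)cc([C@H](CO)[C@H]4CCOC4)c(Cl)c3C2=O)c(=O)[nH]1` holds the lowest of the two single numbers in an assay on cells for inhibition of histone-lysine N-methyltransferase EZH2 (Homo sapiens), read by ELISA, with a stated time of 72 h (a lower number here means a stronger inhibitor, a higher number a weaker inhibitor), where compound 2 gives 10 nM. Within the data shown here, its nearest neighbour is compound 1 `Cc1cc(C)c(CN2CCc3c(Cl)cc([C@@H](C)CO)c(Cl)c3C2=O)c(=O)[nH]1`, which in this assay gives 1040 nM; the change a 100-fold lower number from compound 1 to compound 2 (2.02 log units; beyond the scatter) is the only one-place step measured so far. Compound 3 `Cc1cc(C)c(CN2CCc3c(Cl)cc(C(CO)C4CCOC4)c(Cl)c3C2=O)c(=O)[nH]1` carries no single number: in this assay compound 3 gives 1010 nM; 15 nM (2 entries), and this spread is consistent with the fact that one of compounds 2 and 3 is drawn with a defined configuration and the other without, at the place where they differ read together with the several entries of compound 3 in this assay, 1010 nM; 15 nM (2 entries).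

Compound 4 `Cc1cc(C)c(CN2CCc3c(Cl)cc([C@H](CO)[C@H]4CCCO4)c(Cl)c3C2=O)c(=O)[nH]1` differs from compound 2 by oxolan-2-yl in place of oxolan-3-yl on a saturated chain carbon bound to an aromatic carbon and a saturated chain carbon. Among the measured compounds shown here, no measured step moves the ring oxygen within the oxolanyl group; the measured step of a 100-fold lower number from compound 1 to compound 2 (2.02 log units; beyond the scatter) concerns the arrival of the ring itself at that saturated chain carbon, not the position of its oxygen, so it gives only indirect guidance. The expected step of a 2.5-fold higher number from compound 2 to compound 4 (0.40 log units; beyond the scatter) is therefore small, at most a modest loss that may not exceed the scatter. Compound 4 is estimated at 25 nM in this assay, with a range from 6 nM to 120 nM.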

Compound 4, half-maximal inhibitory concentration in the histone-lysine N-methyltransferase EZH2 assay: 40 nM
Estimate against measurement, compound 4: 1.6-fold (0.20 log units) below, and the stated range covers the measured number.
By their numbers in the histone-lysine N-methyltransferase EZH2 assay, from the lowest: compound 2; then compound 4; then compound 1.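

In the histone-lysine N-methyltransferase EZH2 assay, the place of the ring oxygen matters at this saturated chain carbon, not only the presence of a ring: oxolan-2-yl in place of oxolan-3-yl gives a 4.0-fold higher number from compound 2 to compound 4 (0.60 log units; beyond the scatter). The oxolan-2-yl group still keeps a large part of the gain over methyl, with a 26-fold lower number from compound 1 to compound 4 (1.41 log units; beyond the scatter). In a physicochemical assay for solubility, measured as kinetic solubility (on this read-out lower numbers stand for lower solubility and higher numbers for higher solubility), compound 2 gives 570000 nM and compound 4 gives 430000 nM, two values within the scatter of each other, so on this read-out the pair does not separate.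

Open, going by these compounds, is how other configurations at the saturated chain carbon and in the ring would compare, a question the entries of compound 3 do not settle: the several entries of compound 3 in the histone-lysine N-methyltransferase EZH2 assay, 1010 nM; 15 nM (2 entries) Also open is whether an oxan-4-yl group or a pyrrolidin-3-yl amine at the same place would hold the number in the histone-lysine N-methyltransferase EZH2 assay.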